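Aryl swap on the ring nitrogen: compound 2 to compound 4

The source may hold more compounds than are shown below. What is called first, only, known or untested is meant among the compounds shown, and "the series" means these compounds.

Of the compounds shown here, three have been measured in an assay on isolated protein for inhibition of methionine--tRNA ligase, cytoplasmic (Homo sapiens); a lower number here means a stronger inhibitor, a higher number a weaker inhibitor. Compound 1 `O=C(O)c1cc(-c2ccc(-c3ccc(Cl)cc3Cl)cc2)n(-c2cccnc2)n1` gives 47000 nM. Compound 3 `O=C(O)c1cc(-c2ccc(-c3ccc(F)cc3)cc2)n(-c2ccc(Cl)cc2Cl)n1` gives 41300 nM. Compound 2 `O=C(O)c1cc(-c2ccc(-c3ccc(Cl)cc3Cl)cc2)n(-c2ccccn2)n1` reaches only the limit of this assay, > 100000 nM. Compound 2 therefore stands at the weak end of the three, with a limit rather than a number. Among the compounds with values here, the only measured single-point step, an at least 2.1-fold higher number from compound 1 to compound 2 (0.32 log units; beyond the scatter), went toward weaker inhibition; its true size is open, since one of the two values sits at the limit of > 100000 nM in this assay, at which 1 of the 3 values shown sits.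

Compound 4 `COc1ccc(-n2nc(C(=O)O)cc2-c2ccc(-c3ccc(Cl)cc3Cl)cc2)cc1` differs from compound 2 by 4-methoxyphenyl in place of pyridin-2-yl on an aromatic nitrogen. The step from compound 1 to compound 2 shows that the aryl group on the ring nitrogen matters by at least a modest amount, and compound 3, which carries a carbon-only aryl on that nitrogen, gives 41300 nM. A return toward the range of compound 1 and compound 3 is therefore expected, that is a modest step toward stronger inhibition, an at least 2.0-fold lower number from compound 2 to compound 4 (0.30 log units; that floor lies within the scatter). Compound 4 is estimated at 50000 nM, with a range of 20000 nM to 150000 nM.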

Compound 4, half-maximal inhibitory concentration: > 100000 nM
Compound 4: no number, only a limit; the forecaster's own chance of this, stated with the estimate: 25%; middle value at least 2.0-fold (0.30 log units) away from the limit.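

In this assay compound 4 gives > 100000 nM, which is a limit of the assay and not a number. The change to 4-methoxyphenyl in place of pyridin-3-yl on the aromatic nitrogen gives an at least 2.1-fold higher number from compound 1 to compound 4 (0.32 log units; beyond the scatter), so a second group at this position, now a ring of carbon only, also falls on the weak side of the pyridin-3-yl compound. The step between compound 2 and compound 4 cannot be read, since both values are limits: the limit of > 100000 nM in this assay, at which 2 of the 4 values shown sit.

Going by these compounds, how far compound 2 and compound 4 lie past the limit, and their order, stays open. Also open, on these data alone, is whether another group on this nitrogen, such as a methyl group or a phenyl ring carrying an amine, would match or improve on compound 1.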